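Swapping an Aromatic Ring for a Saturated One

This account rests on a few compounds, and the source may have more. Where it says the series, first, only, none or still open, it means among the compounds named here.

Compound 1 `O=C(/C=C/c1ccccc1Br)Nc1ccc2c(c1)COC2=O` — in a functional assay on cells (T-cell, Mus musculus) for inhibition (on this read-out higher numbers stand for weaker inhibition and lower numbers for stronger inhibition), compound 1 reaches only a limit, > 100000 nM.
Compound 2 `COc1ccccc1/C=C/C(=O)Nc1ccc2c(c1)COC2=O` — in this assay compound 2 gives 39 nM.
Compound 3 `Cc1cccc(NC(=O)Nc2ccc3c(c2)COC3=O)c1` — in this assay compound 3 gives 2260 nM.

Among the two compounds with a number in this assay, compound 3 stands highest, and compound 2 lies well below it, beyond the scatter. Compound 1 contributes no number, only the limit (the limit of > 100000 nM in this assay, at which 1 of the 3 values shown sits). Within the data shown here, the single measured step, an at least 2500-fold lower number from compound 1 to compound 2 (3.40 log units; beyond the scatter), concerns a substituent on an aromatic ring in a part of the molecule that compound 3 and compound 4 share unchanged, so it says nothing about the change studied here.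

Compound 4 `O=C(Nc1ccc2c(c1)COC2=O)NC1CCCCC1` differs from compound 3 by cyclohexyl in place of 3-methylphenyl on an amide-type nitrogen. Among the measured compounds shown here, no measured pair speaks to an aromatic ring giving way to a saturated one at this position, so the direction of the step is unknown and the width of the expectation must be large. Compound 4 is therefore expected to land near compound 3, with the estimated step of a 1.5-fold higher number from compound 3 to compound 4 (0.19 log units; within the scatter) allowing a modest move either way.

For compound 4 in this assay the estimate is 3500 nM, between 600 nM and 20000 nM.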

Compound 4, half-maximal inhibitory concentration: 12700 nM
Compound 4: the middle estimate sits 3.6-fold (0.56 log units) below what was measured, within the range that was stated.
By their numbers in this assay, from the lowest: compound 2; then compound 3; then compound 4. At a limit, above all of these: compound 1.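

Among these compounds, the step gives the first measured reading at this position: in this assay, cyclohexyl in place of 3-methylphenyl on an amide-type nitrogen brings a 5.6-fold higher number from compound 3 to compound 4 (0.75 log units; beyond the scatter). As higher numbers stand for weaker inhibition, the non-aromatic ring gives weaker inhibition than the aromatic ring in this one pair, although compound 4 still gives a measured number rather than a limit. The information shown bears on the size and direction of this step but offers nothing that would explain it.

The change replaces an aromatic ring with a saturated one and also removes the methyl group, so this pair cannot show which of the two differences accounts for the step; an unsubstituted phenyl or a methylcyclohexyl on the same nitrogen would help to separate them. Also open, on these data alone, is whether a ring is needed on this nitrogen at all, a question that an open chain such as n-hexyl, or a ring carrying an amine such as piperidinyl, would address.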